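Ester for amide on the piperidine substituent

The source may hold more compounds than are shown below. What is called first, only, known or untested is meant among the compounds shown, and "the series" means these compounds.

Compound 3 `NC(=O)C1CCCN(C(=O)CN2CN(c3ccccc3)C3(CCN(C(=O)c4ccc(C5CCCCC5)cc4)CC3)C2=O)C1` gives 3100 nM in an assay on HEK293 cells for displacement of a labelled ligand from NPC1-like intracellular cholesterol transporter 1 (Homo sapiens) (on this read-out lower numbers stand for stronger inhibition and higher numbers for weaker inhibition), the highest number of the three measured compounds; compound 1 `COC(=O)CCCNC(=O)CN1CN(c2ccccc2)C2(CCN(C(=O)c3ccc(C4CCCCC4)cc3)CC2)C1=O` gives 2500 nM, within the scatter of compound 3, while compound 2 `O=C(CN1CN(c2ccccc2)C2(CCN(C(=O)c3ccc(C4CCCCC4)cc3)CC2)C1=O)N1CCCCC1` gives 1100 nM, and a 2.8-fold higher number from compound 2 to compound 3 (0.45 log units; beyond the scatter). Compound 4 `CCOC(=O)C1CCCN(C(=O)CN2CN(c3ccccc3)C3(CCN(C(=O)c4ccc(C5CCCCC5)cc4)CC3)C2=O)C1` differs from compound 3 in one place: ethoxy in place of amino on a carbonyl carbon. Going by the values given here, no measured step swaps an amide for an ester directly. The nearest guide is a 2.8-fold higher number from compound 2 to compound 3 (0.45 log units; beyond the scatter), which shows that adding the carbamoyl group cost a modest amount, and a 2.3-fold lower number from compound 1 to compound 2 (0.36 log units; beyond the scatter), where an open-chain amino ester arm sat between compound 2 and compound 3 without a clear advantage. The ester of compound 4 keeps a substituent on the saturated ring carbon, so the number is expected to stay near compound 3 or move modestly lower toward compound 2. The expected step is a 1.6-fold lower number from compound 3 to compound 4 (0.19 log units; within the scatter). Compound 4 is thus estimated at 2000 nM, with a range from 900 nM to 4500 nM.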

Compound 4, half-maximal inhibitory concentration: 4200 nM
Beside the measured number, compound 4's estimate is 2.1-fold (0.32 log units) below it; the measured number falls inside the stated range.
By their numbers in this assay, from the lowest: compound 2; then compounds 1, 3 and 4 (each within the scatter of the next).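

In this assay, changing carbamoyl to ethoxycarbonyl on the saturated ring carbon gives no readable change: a 1.4-fold higher number from compound 3 to compound 4 (0.13 log units; within the scatter), so removing the amino group with its hydrogen-bond donor is tolerated at this position. Relative to the unsubstituted piperidine, the ester also carries a modest penalty, with a 3.8-fold higher number from compound 2 to compound 4 (0.58 log units; beyond the scatter), while its difference from the open-chain ester arm stays unresolved, with a 1.7-fold higher number from compound 1 to compound 4 (0.23 log units; within the scatter). No supporting data bear on why these substituents behave this way.

Still open, going by these compounds, is whether a carboxylic acid or a primary amine on that saturated ring carbon would give a number in the same range. It is also unresolved whether any substituent there can match the unsubstituted compound 2 at 1100 nM.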